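The source may hold more compounds than are shown below. What is called first, only, known or untested is meant among the compounds shown, and "the series" means these compounds.

Measured in an ADME assay on L02 cells (Homo sapiens) for cytotoxicity, read by MTT assay, with a stated time of 24 h; on this read-out higher numbers stand for weaker inhibition and lower numbers for stronger inhibition:

Compound 1, `COc1cc(/C=C2\CN(C)C/C(=C\c3ccc(F)cc3)C2=O)cc(OC)c1OC`, gives 10700 nM.
Compound 2, `COc1cc(/C=C2\CN(C)C/C(=C\c3ccc(Cl)cc3)C2=O)cc(OC)c1OC`, gives 14000 nM.
Compound 3, `CN1C/C(=C\c2ccc(F)cc2)C(=O)/C(=C/c2ccc(C#N)cc2)C1`, gives 20900 nM.

Compound 2 differs from compound 1 by one change, (chloro in place of fluoro on an aromatic carbon), on an aromatic carbon para to a large group. In this assay that change made a 1.3-fold higher number from compound 1 to compound 2 (0.12 log units; within the scatter), a step that the usual scatter of such measurements can account for on its own. Compound 3 rests on a different core; how its core differs from that of compound 1 is not broken down here. Its value and those of compound 1 and compound 2 all lie within the scatter of one another, so no order among the three can be read from these numbers.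

Compound 4, `CN1C/C(=C\c2ccc(Cl)cc2)C(=O)/C(=C/c2ccc(C#N)cc2)C1`, is compound 3 after the same change, (chloro in place of fluoro on an aromatic carbon), again on an aromatic carbon para to a large group. In this assay the expected step is a 1.2-fold higher number from compound 3 to compound 4 (0.09 log units; within the scatter), because a 1.3-fold higher number from compound 1 to compound 2 (0.12 log units; within the scatter) was itself within the scatter and nothing here argues that the change should act differently on the core of compound 3. Compound 4 is therefore expected to give about 26000 nM, with a likely range from 13000 nM to 52000 nM.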

Compound 4, half-maximal inhibitory concentration: 16200 nM
Compound 4: middle estimate off by 1.6-fold (0.21 log units), on the high side; measured number inside the range.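

In this assay, chloro in place of fluoro on the core of compound 3 gave a 1.3-fold lower number from compound 3 to compound 4 (0.11 log units; within the scatter), so this pair of values cannot be told apart. The step on this core and the earlier step point in opposite directions on paper, but the gap between them is no larger than the scatter allows: the same change on two cores in this assay, a 1.3-fold higher number (0.12 log units; within the scatter) from compound 1 to compound 2 and a 1.3-fold lower number (0.11 log units; within the scatter) from compound 3 to compound 4, 1.7-fold (0.23 log units) apart, within the scatter of two such steps. The two pairs therefore give no sign that the core alters what this change does, and in both the change from 4-fluorophenyl to 4-chlorophenyl leaves the values within the scatter, but two small steps cannot show that the cores truly respond alike or that the change has no effect at all.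

The compounds shown leave open whether a bromo group or an amine in the same place would give a step beyond the scatter. Also open, on these data alone, is how the change from fluoro to chloro would behave on further cores.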